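The source may hold more compounds than are shown below. What is called first, only, known or untested is meant among the compounds shown, and "the series" means these compounds.

Measured so far in a functional assay for antagonist activity at transient receptor potential cation channel subfamily V member 1 (Rattus norvegicus), read by FLIPR; on this read-out higher numbers stand for higher potency (the scale is a negative logarithm) and lower numbers for lower potency:
compound 1 `N#Cc1ccc(N2CC[C@@H](NC(=O)Nc3ccccc3Br)C2)nc1`: 6.7
compound 2 `O=C(Nc1ccccc1Br)N[C@@H]1CCN(c2cccc(C(F)(F)F)n2)C1`: 7.2
compound 3 `Cc1ccc(N2CC[C@@H](NC(=O)Nc3ccccc3Br)C2)cc1F`: 8.3

Compound 1 stands lowest of the three numbers; compound 2 lies above it by more than the scatter, and compound 3 furthest above, as a number 1.60 log units higher from compound 1 to compound 3 (beyond the scatter) shows. Compound 4 `O=C(Nc1ccccc1Br)N[C@@H]1CCN(c2ccccn2)C1` differs from compound 1 by hydrogen in place of cyano on an aromatic carbon. Going by the values given here, no measured pair isolates the cyano group: the only known step exchanges the whole aryl ring, and compound 2 only shows that another substituted pyridyl ring gives 7.2 in this assay. The change is small in size, so a step no larger than the gap to compound 2 is expected, a number 0.30 log units higher from compound 1 to compound 4 (within the scatter), direction uncertain. Compound 4 is therefore estimated at 7, with a range from 6.3 to 7.7.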

Compound 4, negative logarithm of the antagonist equilibrium constant: < 6.6
Compound 4: only a limit was reported; the forecaster's own chance of this, stated with the estimate: 10%; middle value at least 0.40 log units away from the limit.
By their numbers in this assay, from the lowest: compound 1; then compound 2; then compound 3. At a limit, below all of these: compound 4.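

In this assay, compound 4 is reported only as a limit: the limit of < 6.6 in this assay, at which 1 of the 4 values shown sits.

Hydrogen in place of cyano gives a number at least 0.10 log units lower from compound 1 to compound 4 (that floor lies within the scatter), so the bare pyridin-2-yl ring is not separated from compound 1, whereas hydrogen in place of trifluoromethyl gives a number at least 0.60 log units lower from compound 2 to compound 4 (beyond the scatter). The bare ring also falls well short of the 3-fluoro-4-methylphenyl group, with a number at least 1.70 log units lower from compound 3 to compound 4 (beyond the scatter).

On these data alone, the actual value of compound 4 remains unknown. Also open, as far as these compounds go, is how an amine or a carboxylic acid would read on this aromatic carbon, two atoms from the ring nitrogen.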